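The compounds below may be only part of what the source reports. "The series", "measured", "known", "first", "only" and "open" are said of these compounds alone.

Measured so far in a functional assay on HeLa cells (Homo sapiens) for cytotoxicity, read by MTT assay, with a stated time of 2 days, tested at 100 uM; on this read-out higher numbers stand for a weaker effect at the one concentration tested and lower numbers for a stronger effect:
compound 1, `CC(=O)c1cc(-c2ccc(F)cc2)cc2cc(-c3ccc(F)cc3)[nH]c12`, 9.31%;
compound 2, `COc1ccc(-c2cc3cc(-c4ccc(F)cc4)cc(C(C)=O)c3[nH]2)cc1`, 46.5%;
compound 3, `CC(=O)c1cc(/C=C/c2ccc(F)cc2)cc2cc(-c3ccc(F)cc3)[nH]c12`, 20.3%.

Compound 4, `COc1ccc(-c2cc3cc(/C=C/c4ccc(F)cc4)cc(C(C)=O)c3[nH]2)cc1`, has not yet been measured in this assay. It differs from compound 3 by methoxy in place of fluoro on an aromatic carbon, and the same change has already been made once among the measured compounds, from compound 1 to compound 2: methoxy in place of fluoro on an aromatic carbon. That step gave a number 37.2 percentage points higher from compound 1 to compound 2 (beyond the scatter). The two cores on which the change is made are not identical; compound 3 differs from compound 1 by 2-(4-fluorophenyl)ethenyl in place of 4-fluorophenyl on an aromatic carbon, and that step by itself gave a number 11 percentage points higher from compound 1 to compound 3 (beyond the scatter). The place of the methoxy-for-fluoro change is described in the same words in both pairs, so it is the same change on a slightly altered core.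

Resting on the single earlier step from compound 1 to compound 2, the step from compound 3 to compound 4 is expected to be a number 34.7 percentage points higher from compound 3 to compound 4 (beyond the scatter). Among the measured compounds shown here, with only one precedent, the expected range is wide. Compound 4 is therefore estimated at 55% in this assay, from 35% to 75%.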

Compound 4, a percentage reported as activity, at one concentration (the size of the read-out at that concentration, not a potency): 18.9%
For compound 4 the middle estimate is 36.1 percentage points above the measured one; measured number below the stated range.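

In this assay, the methoxy-for-fluoro change on the core carrying the 2-(4-fluorophenyl)ethenyl group gave a number 1.4 percentage points lower from compound 3 to compound 4 (within the scatter), and set beside the earlier step this shows that the change did not carry over from one core to the other: the same change on two cores in this assay, a number 37.2 percentage points higher (beyond the scatter) from compound 1 to compound 2 and a number 1.4 percentage points lower (within the scatter) from compound 3 to compound 4, 38.6 percentage points apart, beyond the scatter of two such steps

Read the other way, the change from 4-fluorophenyl to 2-(4-fluorophenyl)ethenyl gave a number 27.6 percentage points lower from compound 2 to compound 4 (beyond the scatter), so its step also differed according to whether methoxy or fluoro was present: the same change on two cores in this assay, a number 11 percentage points higher (beyond the scatter) from compound 1 to compound 3 and a number 27.6 percentage points lower (beyond the scatter) from compound 2 to compound 4, 38.6 percentage points apart, beyond the scatter of two such steps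

Thus the two changes do not simply add up across these four compounds, but this single set of four does not show why, nor whether the same would hold on any further core.

The compounds shown leave open how an amine or a carboxylic acid in place of the fluoro or methoxy would behave on either core. They also leave open what a longer chain in place of the ethenyl group would do, and a read-out at one concentration gives no potency for any of them.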